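The compounds below may be only part of what the source reports. "The series", "measured", "known", "first", "only" and "open" are said of these compounds alone.

Measured compounds:
compound 1 `Cc1c(C(=O)N=C(N)N)cc(S(C)(=O)=O)c(Cl)c1Cl` – 29 nM
compound 2 `Cc1c(C(=O)N=C(N)N)cc(S(C)(=O)=O)c(Cl)c1[N+](=O)[O-]` – 44 nM
compound 3 `Cc1cc(-c2ccc(Cl)cc2)c(S(C)(=O)=O)cc1C(=O)N=C(N)N` – 45 nM

All three were read in a functional assay for inhibition of sodium/hydrogen exchanger (Oryctolagus cuniculus); a lower number here means a stronger inhibitor, a higher number a weaker inhibitor. Compound 3 sits within the scatter of both others; its number and that of compound 2 are practically the same, and the gap to compound 1 is also inside the scatter. Among the compounds with values here, the only single-point step on record, a 1.5-fold higher number from compound 1 to compound 2 (0.18 log units; within the scatter), concerns a change at a different place on the shared core and is itself within the scatter. Compound 4 `Cc1cc(Sc2ccncc2)c(S(C)(=O)=O)cc1C(=O)N=C(N)N` is the next candidate; it differs from compound 3 by (pyridin-4-yl)sulfanyl in place of 4-chlorophenyl on an aromatic carbon. Within the data shown here, no measured step touches that group or that place, so no direction is supported; the step is expected to be no change at the digits printed from compound 3 to compound 4 (within the scatter), i.e. none beyond the scatter. In this assay compound 4 is accordingly expected at 45 nM, estimated range 15 nM to 140 nM.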

Compound 4, half-maximal inhibitory concentration: 13 nM
Beside the measured number, compound 4's estimate is 3.5-fold (0.54 log units) above it, and the stated range ends above it.
By their numbers in this assay, from the lowest: compound 4; then compounds 1, 2 and 3 (each within the scatter of the next).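

Within the data shown here, on the aromatic carbon ortho to a methylsulfonyl group, (pyridin-4-yl)sulfanyl in place of 4-chlorophenyl gives a 3.5-fold lower number from compound 3 to compound 4 (0.54 log units; beyond the scatter) in this assay and is the only recorded step that passes the scatter. The number therefore does respond to the group at this position. No measurement available here accounts for the step.

Going by these compounds, the change replaces the sulfur link and the ring together, so their separate contributions remain open. On these data alone, whether phenylsulfanyl, directly attached pyridin-4-yl or an amine here would give a similar number also remains open.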